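A few compounds are considered here, and "the series" means these few. Any claim that something is new, unique, unknown or untested is made for them only; others in the source may bear on it.

Compound 2 `c1cc(C2=NNC(c3ccc(N4CCCCC4)cc3)C2)cs1` is tested in an ADME assay on CCRF-CEM cells (Homo sapiens) for cytotoxicity, with a stated time of 5 days (a higher number here means a weaker inhibitor, a lower number a stronger inhibitor), and gives 27000 nM. Compound 1 `O=C(/C=C/c1ccc(N2CCCCC2)cc1)c1ccc(Cl)s1` gives 41500 nM in this assay; the two numbers lie within the usual scatter of each other, so neither can be set apart from the other. Compound 3 `Brc1ccsc1C1=NNC(c2ccc(N3CCCCC3)cc2)C1` carries 3-bromothiophen-2-yl in place of thiophen-3-yl on a carbon with a double bond to nitrogen, leaving the rest of compound 2 unchanged. Going by the values given here, no measured pair shows what such a change does here, so the step from compound 2 to compound 3 is expected to stay within the scatter, as a 1.1-fold lower number from compound 2 to compound 3 (0.03 log units; within the scatter). Compound 3 is therefore estimated at 25000 nM, between 8000 nM and 80000 nM, in this assay.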

Compound 3, half-maximal inhibitory concentration: 31600 nM
For compound 3 the middle estimate is 1.3-fold (0.10 log units) below the measured one; the measured number falls inside the stated range.
By their numbers in this assay, from the lowest: compounds 2, 3 and 1 (each within the scatter of the next).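

In this assay, 3-bromothiophen-2-yl in place of thiophen-3-yl on a carbon with a double bond to nitrogen gives a 1.2-fold higher number from compound 2 to compound 3 (0.07 log units; within the scatter), so the bromine and the shifted ring attachment together leave no change that can be told from the scatter. Going by these compounds alone, this is the only measured step at this position, and it is a small one. Nothing at hand accounts for this result. Going by these compounds, whether an amine or a carboxylic acid on the thiophene ring would move the number beyond the scatter remains open. So does what the bromine and the shifted attachment each do alone.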